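The source may report more compounds than this note shows. Statements on the series, on what has been measured and on what is new or still open speak of the compounds shown alone.

Compound 1 `NNC(=O)c1c(N)sc2c1CCCCCC2` — in a functional assay on CHO cells for agonist activity at adenosine receptor A1 (Homo sapiens), read by ERK phosphorylation, tested at 3 uM (on this read-out lower numbers stand for a weaker effect and higher numbers for a stronger effect at the one concentration tested), compound 1 gives 48%
Compound 2 `Cc1ccc(C(=O)c2c(N)sc3c2CCCCCC3)cc1` — in this assay compound 2 gives 56%
Compound 3 `Nc1sc2c(c1C(=O)c1cccc(C(F)(F)F)c1)CCCCCC2` — in this assay compound 3 gives 57%

Compound 3 holds the highest of the three numbers, yet its gaps to compound 2 and to compound 1 both fall within the scatter, so the three measured compounds cannot be placed in any order on this read-out. Among the measured compounds shown here, the single measured step in the set, a number 8 percentage points higher from compound 1 to compound 2 (within the scatter), comes from exchanging 4-methylphenyl for aminoamino on a carbonyl carbon, and it too stayed within the scatter.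

Compound 4 `Nc1sc2c(c1C(=O)c1ccccc1)CCCCCC2` has not yet been measured. It differs from compound 3 by hydrogen in place of trifluoromethyl on an aromatic carbon. For the measured compounds named here, no measured step changes a substituent on the aromatic ring, so the step between compound 1 and compound 2 bears on this change only loosely, as a sign that a change on the carbonyl side of the shared core moved the read-out little. All three measured numbers sit in a narrow band. Compound 4 is therefore expected to stay in that band, with a step of a number 3 percentage points lower from compound 3 to compound 4 (within the scatter) expected to be no larger than the scatter. Compound 4 is accordingly estimated at 54%, with a range from 40% to 68%.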

Compound 4, a percentage reported as activity, at one concentration (the size of the read-out at that concentration, not a potency): 49%
Compound 4: middle estimate off by 5 percentage points, on the high side, within the range that was stated.
By their numbers in this assay, from the lowest: compounds 1, 4, 2 and 3 (each within the scatter of the next).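

In this assay, among the compounds shown here, the steps on the aromatic ring itself are a number 8 percentage points lower from compound 3 to compound 4 (within the scatter) for the loss of trifluoromethyl and a number 7 percentage points lower from compound 2 to compound 4 (within the scatter) for the loss of methyl, so neither substituent can be told apart from plain hydrogen on this read-out, which no earlier step could show. On the carbonyl carbon, the unsubstituted phenyl in place of aminoamino gives a number 1 percentage points higher from compound 1 to compound 4 (within the scatter) and so adds a second carbonyl-side exchange that stays inside the scatter, this time without any ring substituent involved. Nothing measured here bears on why these steps are as small as they are.

Across these four compounds, then, neither the ring substituents nor the exchange of aminoamino for an aryl group separates one compound from another, and this holds only for the single concentration tested, which gives no potency. Still open, going by these compounds, is whether a carboxylic acid, an amine or a methoxy group on that aromatic carbon, or a saturated cyclohexyl ring or a short alkyl chain in place of phenyl on the carbonyl carbon, would produce a step beyond the scatter.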